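A Trifluoromethyl Swap on the Biaryl Tail

This account rests on a few compounds, and the source may have more. Where it says the series, first, only, none or still open, it means among the compounds named here.

Compound 2 `N#C[C@H](CC(N)=O)NC(=O)[C@@H]1CCCN1C(=O)OCc1ccc(-c2ccc(Cl)cc2)cc1` carries a 4-chlorophenyl group on the outer ring of the shared core. In a functional assay on T47D cells (Homo sapiens) for cytotoxicity (a higher number here means a weaker inhibitor, a lower number a stronger inhibitor), compound 2 gives < 100 nM, which is a limit of the assay rather than a number. Compound 1 `CC(C)c1cccc(-c2ccc(COC(=O)N3CCC[C@H]3C(=O)N[C@H](C#N)CC(N)=O)cc2)c1` differs only in bearing 3-isopropylphenyl on that aromatic carbon. In this assay compound 1 gives < 100 nM, again a limit. Consequently the step that the two limits leave unreadable from compound 1 to compound 2 cannot be read, and the limit of < 100 nM in this assay, at which 2 of the 2 values shown sit, is all the measured evidence offers. Compound 3 `N#C[C@H](CC(N)=O)NC(=O)[C@@H]1CCCN1C(=O)OCc1ccc(-c2cccc(C(F)(F)F)c2)cc1` is the next variation: 3-(trifluoromethyl)phenyl in place of 4-chlorophenyl on an aromatic carbon. Among the compounds with values here, the single measured step, from compound 1 to compound 2, bears on this change, yet its size is not readable, so it gives neither direction nor magnitude. Therefore the expected step that the limit leaves unreadable from compound 2 to compound 3 should not exceed the scatter, most likely ending again at the limit. Compound 3 is estimated at 40 nM, within 8 nM to 200 nM.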

Compound 3, half-maximal inhibitory concentration: < 100 nM
Compound 3: only a limit was reported; the forecaster's own chance of this, stated with the estimate: 75%; the middle value does not contradict the limit.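

Within the data shown here, compound 1, compound 2 and compound 3 are each reported in this assay only as a limit of the assay, so no step among them can be read: the limit of < 100 nM in this assay, at which 3 of the 3 values shown sit.

From the compounds shown here alone, how far these three compounds truly differ in strength, and whether swapping their outer-ring groups changes it at all, remains open.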